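From Cyano to Methoxy on the Shared Core

The source may report more compounds than this note shows. Statements on the series, on what has been measured and on what is new or still open speak of the compounds shown alone.

Of the compounds shown here, three sharing one core have been measured in a functional assay on HEK293 cells for agonist activity at Neuronal acetylcholine receptor; alpha3/beta4 (Homo sapiens), read by FLIPR; a lower number here means that less compound is needed, a higher number that more compound is needed for the effect. Compound 1 `c1cncc(N2CC[C@H]3CN[C@H]3C2)c1` gives 48 nM, compound 2 `Brc1cncc(N2CC[C@H]3CN[C@H]3C2)c1` gives 76 nM, and compound 3 `N#Cc1cncc(N2CC[C@H]3CN[C@H]3C2)c1` gives 1000 nM. Compound 3 therefore holds the highest number of the three: the step of a 21-fold higher number from compound 1 to compound 3 (1.32 log units; beyond the scatter) and the step of a 13-fold higher number from compound 2 to compound 3 (1.12 log units; beyond the scatter) both show that placing cyano on the aromatic carbon raised the number markedly, whereas a 1.6-fold higher number from compound 1 to compound 2 (0.20 log units; within the scatter) stayed within the scatter. Compound 4 `COc1cncc(N2CC[C@H]3CN[C@H]3C2)c1` carries methoxy in place of cyano on an aromatic carbon. For the measured compounds named here, no measured step involves methoxy itself, but both steps that introduced cyano were large, so removing cyano is expected to lower the number substantially. For compound 4 a value of 100 nM is estimated, within 35 nM to 300 nM. The expected step of a 10-fold lower number from compound 3 to compound 4 (1.00 log units; beyond the scatter) would land near the numbers seen before cyano was present.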

Compound 4, half-maximal effective concentration: 180 nM
Compound 4: the middle estimate sits 1.8-fold (0.26 log units) below what was measured; the measured number falls inside the stated range.
By their numbers in this assay, from the lowest: compounds 1 and 2 (each within the scatter of the next); then compound 4; then compound 3.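

Swapping cyano for methoxy, two groups with the same count of heavy atoms, gives a 5.6-fold lower number from compound 3 to compound 4 (0.74 log units; beyond the scatter) and so recovers much of the loss seen with cyano. Methoxy still does not match the earlier compounds, with a 2.4-fold higher number from compound 2 to compound 4 (0.37 log units; beyond the scatter) and a 3.8-fold higher number from compound 1 to compound 4 (0.57 log units; beyond the scatter) as the gaps that remain, so cyano is not the only group at this position that moves the number beyond the scatter. As far as these compounds go, how an amine or a longer chain such as ethoxy would behave at this position remains open. No measurement at hand gives a reason for any of these steps.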